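Replacing a Leucine-like Side Chain with a Second Ester

This account rests on a few compounds, and the source may have more. Where it says the series, first, only, none or still open, it means among the compounds named here.

Three measured compounds share one core and differ only in the side chain of the amino-acid ester attached through the amide. Compound 1 `CC[C@H](C)[C@@H](NC(=O)Cn1cc(C2=C(c3c[nH]c4ccccc34)C(=O)N(C)C2=O)c2ccccc21)C(=O)OC` carries a sec-butyl group there. In a functional assay on BGC-823 cells (Homo sapiens) for cytotoxicity, read by MTT assay, with a stated time of 24 h (on this read-out higher numbers stand for weaker inhibition and lower numbers for stronger inhibition), compound 1 reaches only the limit of the assay, > 100000 nM, as noted in the limit of > 100000 nM in this assay, at which 1 of the 3 values shown sits. Compound 2 `COC(=O)[C@H](NC(=O)Cn1cc(C2=C(c3c[nH]c4ccccc34)C(=O)N(C)C2=O)c2ccccc21)[C@@H](C)O` carries a 1-hydroxyethyl group, and in this assay compound 2 gives 23300 nM. Compound 3 `COC(=O)[C@@H](CC(C)C)NC(=O)Cn1cc(C2=C(c3c[nH]c4ccccc34)C(=O)N(C)C2=O)c2ccccc21` carries an isobutyl group, and in this assay compound 3 gives 45500 nM, the higher of the two real numbers, although the gap a 2.0-fold higher number from compound 2 to compound 3 (0.29 log units; within the scatter) is within the scatter. The steps of an at least 4.2-fold lower number from compound 1 to compound 2 (0.63 log units; beyond the scatter) and an at least 2.1-fold lower number from compound 1 to compound 3 (0.34 log units; beyond the scatter) both move away from the limit.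

Compound 4 `COC(=O)C[C@@H](NC(=O)Cn1cc(C2=C(c3c[nH]c4ccccc34)C(=O)N(C)C2=O)c2ccccc21)C(=O)OC` has not been measured. It differs from compound 3 by methoxycarbonyl in place of isopropyl on a saturated chain carbon, two bonds along the chain from an amide-type nitrogen and a carbonyl carbon. For the measured compounds named here, no measured step makes exactly this exchange. The closest guide is the step of a 2.0-fold higher number from compound 2 to compound 3 (0.29 log units; within the scatter), where a hydroxyl-bearing side chain and an isobutyl side chain gave numbers within the scatter of each other, and the step of an at least 4.2-fold lower number from compound 1 to compound 2 (0.63 log units; beyond the scatter), where the hydroxy group brought a lower number. Compound 4 is therefore expected to show a step of a 1.5-fold lower number from compound 3 to compound 4 (0.18 log units; within the scatter), at most modest. The estimate for compound 4 is 30000 nM, with a range from 10000 nM to 100000 nM.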

Compound 4, half-maximal inhibitory concentration: 24600 nM
Compound 4: the middle estimate sits 1.2-fold (0.09 log units) above what was measured; low and high end bracket the measured number.
By their numbers in this assay, from the lowest: compounds 2, 4 and 3 (each within the scatter of the next). At a limit, above all of these: compound 1.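

In this assay, methoxycarbonyl in place of isopropyl on a saturated chain carbon, two bonds along the chain from an amide-type nitrogen and a carbonyl carbon, gives a 1.8-fold lower number from compound 3 to compound 4 (0.27 log units; within the scatter), and (methoxycarbonyl)methyl in place of 1-hydroxyethyl gives a 1.1-fold higher number from compound 2 to compound 4 (0.02 log units; within the scatter), so this position accepts a second ester with no difference that can be told from the isobutyl or the 1-hydroxyethyl side chain. The sec-butyl side chain is the only one that stands apart, with an at least 4.0-fold lower number from compound 1 to compound 4 (0.60 log units; beyond the scatter). The figure for compound 1 is a limit and not a number: the limit of > 100000 nM in this assay, at which 1 of the 4 values shown sits.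

The compounds shown leave open what a carboxylic acid in place of the methyl ester, an amine on this side chain, or a longer chain carrying the methoxycarbonyl would give. The three real numbers lie within the scatter of their neighbours, and nothing here says whether any group at this position could separate itself from them by a step beyond the scatter.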